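A few compounds are considered here, and "the series" means these few. Any claim that something is new, unique, unknown or untested is made for them only; others in the source may bear on it.

Measured so far in a functional assay on J774 cells (Mus musculus) for cytotoxicity, read by resazurin assay, with a stated time of 72 h; on this read-out lower numbers stand for stronger inhibition and higher numbers for weaker inhibition:
compound 1 `O=S(=O)(Nc1cc(CO)ccc1O)c1ccc(-c2ccc(F)cc2F)cc1` gives 200 nM
compound 2 `O=S(=O)(Nc1cccc(CO)c1)c1ccc(-c2ccc(F)cc2F)cc1` gives 300 nM

Compound 2 and compound 1 sit within the scatter of each other, as the step of a 1.5-fold higher number from compound 1 to compound 2 (0.18 log units; within the scatter) shows. Compound 3 `Cc1c(CO)cccc1NS(=O)(=O)c1ccc(-c2ccc(F)cc2F)cc1` differs from compound 2 by methyl in place of hydrogen on an aromatic carbon. Within the data shown here, the only measured step, a 1.5-fold higher number from compound 1 to compound 2 (0.18 log units; within the scatter), concerns a different change at a different place, so it says little about this one; no comparable step has been measured. With nothing pointing either way, no change beyond the scatter is expected in this assay. Compound 3 is therefore estimated at 300 nM, with a range from 100 nM to 1000 nM. The expected step is no change at the digits printed from compound 2 to compound 3 (within the scatter).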

Compound 3, half-maximal inhibitory concentration: 80 nM
Compound 3: middle estimate off by 3.8-fold (0.57 log units), on the high side; the whole stated range lies above it.
By their numbers in this assay, from the lowest: compound 3; then compounds 1 and 2 (each within the scatter of the next).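

In this assay, methyl in place of hydrogen on the aromatic carbon ortho to the hydroxymethyl group gives a step beyond the scatter (a 3.8-fold lower number from compound 2 to compound 3 (0.57 log units; beyond the scatter)), which the earlier pair, differing by a hydroxy group, did not. This carbon therefore responds to a single added methyl. Compound 3 also separates from compound 1 (a 2.5-fold lower number from compound 1 to compound 3 (0.40 log units; beyond the scatter)), though no measurement shown gives a reason for either shift. As far as these compounds go, whether ethyl, methoxy or an amine on the same carbon would lower the number further remains open. So does whether methyl would act the same way on another ring carbon.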